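Fluoro-to-hydrogen step on the core of compound 1

The source may hold more compounds than are shown below. What is called first, only, known or untested is meant among the compounds shown, and "the series" means these compounds.

compound 1 `CCc1nc(NC(CC)CC)c(F)nc1-c1ccc(Cl)cc1Cl` — 1.22 h
compound 2 `CCCN(CC1CC1)c1nc(CC)c(-c2ccc(Cl)cc2Cl)nc1CC` — 0.2 h
compound 3 `CCc1nc(-c2ccc(OC)cc2C(F)(F)F)c(CC)nc1NC(CC)CC` — 0.2 h

In an in vitro ADME assay on microsomes (Homo sapiens) for metabolic stability (on this read-out lower numbers stand for a shorter-lived compound and higher numbers for a longer-lived compound), compound 1 gives 1.22 h, the highest of the three numbers shown. Compound 2 gives 0.2 h and compound 3 gives 0.2 h; both sit far below compound 1, and both gaps are beyond the scatter. Compound 2 and compound 3 show the same number, so no order between them is claimed.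

Compound 4 `CCc1nc(NC(CC)CC)cnc1-c1ccc(Cl)cc1Cl` has not been measured in this assay. It differs from compound 1 in one place: hydrogen in place of fluoro on an aromatic carbon. The whole of the rest of compound 1 is kept, so the comparison rests on a single fluorine atom removed from an aromatic carbon of a six-membered aromatic ring with 2 nitrogen, next to the ring nitrogen.

Among the measured compounds shown here, no measured pair carries this change, so its size cannot be read from the data. The expectation is a small step toward a shorter-lived compound, close to the edge of the scatter rather than clearly beyond it; the estimated step is a 1.7-fold lower number from compound 1 to compound 4 (0.24 log units; within the scatter). Compound 4 is expected to give about 0.7 h in this assay, with a range from 0.25 h to 1.8 h.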

Compound 4, half-life: 0.467 h
Compound 4: middle estimate off by 1.5-fold (0.18 log units), on the high side; low and high end bracket the measured number.
By their numbers in this assay, from the lowest: compounds 2 and 3 (each within the scatter of the next); then compound 4; then compound 1.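

Among the compounds shown here, the only single-place pair puts a number on this carbon, the one ortho to a (pentan-3-yl)amino group and next to the ring nitrogen: in this assay, hydrogen in place of fluoro gives a 2.6-fold lower number from compound 1 to compound 4 (0.42 log units; beyond the scatter) and the step is modest but readable. For the compounds shown here, with the rest of compound 1 kept, the read-out therefore responds to the loss of this one fluorine atom, which the differences among the earlier compounds could not show. Nothing available bears on what lies behind the step.

From the compounds shown here alone, whether the fluoro itself is special at this carbon stays open, since a chloro, a methyl or a nitrile here, each on the otherwise unchanged structure of compound 1, would be needed to separate the two ends of this change from other possible substituents. Compound 2 and compound 3 appear to carry an ethyl group at this carbon, but each also differs from compound 1 elsewhere, so whether the step holds the same size with other amine or aryl groups remains unresolved.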